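Iodo in place of fluoro on the aryl group

The source may report more compounds than this note shows. Statements on the series, on what has been measured and on what is new or still open speak of the compounds shown alone.

Two compounds sharing the core carry different aryl groups on an amide-type nitrogen. Compound 1 `Cc1cccc(NC(=O)Nc2ccc3c(c2)COC3=O)c1` gives 2260 nM in a functional assay on cells (T-cell, Mus musculus) for inhibition; on this read-out higher numbers stand for weaker inhibition and lower numbers for stronger inhibition. Compound 2 `O=C(Nc1ccc(F)cc1)Nc1ccc2c(c1)COC2=O` gives 4190 nM in this assay. Within the data shown here, the single measured step, a 1.9-fold higher number from compound 1 to compound 2 (0.27 log units; within the scatter), corresponds to 4-fluorophenyl in place of 3-methylphenyl. Among the measured compounds shown here, on these two numbers compound 2 sits at the upper position, but its only neighbour is compound 1 and the gap between them is within the scatter, so the two cannot be ordered.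

Compound 3 `O=C(Nc1ccc(I)cc1)Nc1ccc2c(c1)COC2=O` is not yet measured. The change from compound 2 is iodo in place of fluoro on an aromatic carbon. For the measured compounds named here, no measured step exchanges one halogen for another; the only step on record, a 1.9-fold higher number from compound 1 to compound 2 (0.27 log units; within the scatter), altered the whole aryl substitution pattern and stayed within the scatter. Nothing in the series therefore argues for a shift beyond the scatter in this assay in either direction, and compound 3 is expected to land close to compound 2, the expected step being a 1.4-fold lower number from compound 2 to compound 3 (0.15 log units; within the scatter). The estimate for compound 3 is 3000 nM, with a range of 900 nM to 10000 nM.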

Compound 3, half-maximal inhibitory concentration: 1370 nM
Beside the measured number, compound 3's estimate is 2.2-fold (0.34 log units) above it; measured number inside the range.
By their numbers in this assay, from the lowest: compounds 3, 1 and 2 (each within the scatter of the next, the first and the last beyond it).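

In this assay, among these compounds, swapping one halogen for another on the same aromatic carbon gives a 3.1-fold lower number from compound 2 to compound 3 (0.49 log units; beyond the scatter), the first step to lie beyond the scatter. This position therefore responds to the atom it carries, and the modest step favours iodo over fluoro, while the ranking of aryl groups remains only partly resolved: a 1.6-fold lower number from compound 1 to compound 3 (0.22 log units; within the scatter) leaves 4-iodophenyl and 3-methylphenyl unordered, and compound 1 lies within the scatter of both halogen compounds. Nothing measured here indicates which feature of the exchange of fluoro for iodo lies behind the step.

On these data alone, with only fluoro and iodo compared at this place, it remains open whether chloro or bromo would give numbers lying between those of compound 2 and compound 3, or whether a group other than a halogen, such as methoxy or trifluoromethyl, would match iodo. As far as these compounds go, it also remains open whether the gain seen with iodo would persist alongside a second substituent on the same aryl group, such as the methyl group of compound 1.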